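The source may hold more compounds than are shown below. What is called first, only, known or untested is meant among the compounds shown, and "the series" means these compounds.

Three measured compounds share a core and differ only in the group on an aromatic nitrogen. Compound 1 `Cc1ccccc1-c1nn(C(C)C)cc1CNCCN1CCN(C)CC1` carries an isopropyl group there. In an ADME assay on Huh-7 cells (Homo sapiens) for cytotoxicity (a lower number here means that less compound is tolerated, a higher number that more compound is tolerated), compound 1 gives > 20000 nM, which is a limit of the assay and not a number. Compound 2 `Cc1ccccc1-c1nn(-c2cccc(C(F)(F)F)c2)cc1CNCCN1CCN(C)CC1` carries a 3-(trifluoromethyl)phenyl group, and in this assay compound 2 gives 18000 nM. Compound 3 `Cc1ccccc1-c1nn(Cc2ccccc2)cc1CNCCN1CCN(C)CC1` carries a benzyl group. In this assay compound 3 gives > 20000 nM, again a limit of the assay. So compound 3 stands at the limit, as the evidence notes (the limit of > 20000 nM in this assay, at which 2 of the 3 values shown sit), and only that limit is known for it.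

The step from compound 3 to compound 4 `Cc1ccccc1-c1nn(-c2ccc(N)cc2)cc1CNCCN1CCN(C)CC1` is 4-aminophenyl in place of benzyl on an aromatic nitrogen. Among the measured compounds shown here, two measured steps touch the same position. For the measured compounds named here, from compound 1 to compound 3 the step is a step that the two limits leave unreadable from compound 1 to compound 3, and from compound 2 to compound 3 it is an at least 1.1-fold higher number from compound 2 to compound 3 (0.04 log units; that floor lies within the scatter); the one readable change at this position, an at least 1.1-fold lower number from compound 1 to compound 2 (0.04 log units; that floor lies within the scatter), stays within the scatter. Nothing here points to a step beyond the scatter in this assay, and compound 4 is therefore expected to give 20000 nM, with a range from 10000 nM to 40000 nM, meaning an expected step of a number no higher from compound 3 to compound 4 (the limit leaves the size open) from compound 3 to compound 4.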

Compound 4, half-maximal cytotoxic concentration: > 20000 nM
Compound 4 ended at the assay's limit (the forecaster's own chance of this, stated with the estimate: 55%); the middle value lies on the limit itself.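

The aromatic nitrogen now carries 4-aminophenyl, which has a hydrogen-bond donor and a hydrogen-bond acceptor where benzyl has none, yet in this assay compound 4 sits at the limit, as compound 1 and compound 3 do. Among the compounds shown here, compound 2, with its 3-(trifluoromethyl)phenyl group, had been the only compound with an actual number, and compound 4 shows that a substituted phenyl group on this nitrogen need not give one. For the compounds shown here, the only readable comparison is an at least 1.1-fold higher number from compound 2 to compound 4 (0.04 log units; that floor lies within the scatter), while the other two steps into this compound join two limits and cannot be read.

The compounds shown leave open how far any of the limit compounds lies from the others, so neither benzyl, isopropyl nor 4-aminophenyl can be ranked at this position. They also leave open whether a carboxylic acid on the phenyl ring, a longer alkyl chain on the nitrogen or a change to the piperazine-bearing amine chain would give a number in this assay, and the series so far offers little to compare: the limit of > 20000 nM in this assay, at which 3 of the 4 values shown sit.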